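A Methyl in Place of Nitro: Cytotoxicity Outlook for Compound 4

This account rests on a few compounds, and the source may have more. Where it says the series, first, only, none or still open, it means among the compounds named here.

Compound 1, `O=C(/C=C\c1ccccc1O)N1N=C(c2ccncc2)OC1c1c[nH]c2ccccc12`, in an ADME assay on A549 cells (Homo sapiens) for cytotoxicity, read by MTT assay, with a stated time of 48 h (on this read-out higher numbers stand for weaker inhibition of growth and lower numbers for stronger inhibition of growth), gives > 30 ug/mL, a limit of the assay.
Compound 2, `O=C(/C=C\c1ccc(O)cc1)N1N=C(c2ccncc2)OC1c1c[nH]c2ccccc12`, gives > 30 ug/mL, likewise a limit.
Compound 3, `O=C(/C=C\c1ccc([N+](=O)[O-])cc1)N1N=C(c2ccncc2)OC1c1c[nH]c2ccccc12`, gives > 30 ug/mL, again a limit.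

Compound 3 therefore stands at the limit of > 30 ug/mL in this assay, at which 3 of the 3 values shown sit, with no number of its own. Compound 4, `Cc1ccc(/C=C\C(=O)N2N=C(c3ccncc3)OC2c2c[nH]c3ccccc23)cc1`, differs from compound 3 by methyl in place of nitro on an aromatic carbon. The measured steps that touch the same aryl ring, a step that the two limits leave unreadable from compound 1 to compound 2, a step that the two limits leave unreadable from compound 1 to compound 3 and a step that the two limits leave unreadable from compound 2 to compound 3, are all unreadable, so neither a size nor a direction can be drawn from them; nothing measured points to a step beyond the scatter. Compound 4 is expected to give 40 ug/mL, within a range from 15 ug/mL to 100 ug/mL, most likely again reported only as a limit. The step this estimate implies is a step that the limit leaves unreadable from compound 3 to compound 4, which is expected to stay within the scatter.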

Compound 4, concentration for 50% growth inhibition: > 30 ug/mL
Compound 4 ended at the assay's limit; the forecaster's own chance of this, stated with the estimate: 80%; the middle value is on the limit's open side.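

In this assay compound 4 gives > 30 ug/mL, a limit of the assay. Going by these compounds alone, no step between compound 4 and compound 1, compound 2 or compound 3 can be read. The compounds shown leave open how strongly any of the four inhibits growth: the limit of > 30 ug/mL in this assay, at which 4 of the 4 values shown sit.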